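Removing the Ring Fluorine from a Thromboxane Receptor Blocker

The source may report more compounds than this note shows. Statements on the series, on what has been measured and on what is new or still open speak of the compounds shown alone.

Compound 2 `O=C(O)CC/C=C\C[C@H]1[C@H](F)CC[C@@H]1NS(=O)(=O)c1ccc(F)cc1` was tested in a functional assay on a cell-free system (plasma) for inhibition of thromboxane A2 receptor (Homo sapiens), read by turbidimetry (a lower number here means a stronger inhibitor, a higher number a weaker inhibitor), where compound 2 gives 750 nM. Among the two compounds with a single number, compound 2 holds the lower one. Compound 1 `O=C(O)CCCCCC[C@H]1[C@H](F)CC[C@@H]1NS(=O)(=O)c1ccc(F)cc1` gives 2400 nM. The step of a 3.2-fold lower number from compound 1 to compound 2 (0.51 log units; beyond the scatter) exchanges a 5-carboxypentyl chain for a 4-carboxybut-1-en-1-yl chain. Compound 3 `O=C(O)CCC/C=C\C[C@H]1[C@H](F)CC[C@@H]1NS(=O)(=O)c1ccc(F)cc1` was measured twice and gives 540 nM; 540 nM (2 entries). Compound 4 `O=C(O)CC/C=C\C[C@H]1[C@H](F)CC[C@@H]1NS(=O)(=O)c1ccccc1` differs from compound 2 by hydrogen in place of fluoro on an aromatic carbon. Among the measured compounds shown here, none of the measured steps touches the aromatic ring; the only known step alters the chain. With no guide for this change, no shift beyond the scatter is expected. Compound 4 is estimated at 900 nM, within 300 nM to 2700 nM. The step of a 1.2-fold higher number from compound 2 to compound 4 (0.08 log units; within the scatter) is expected to be small.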

Compound 4, half-maximal inhibitory concentration: 2000 nM
Compound 4: the middle estimate sits 2.2-fold (0.35 log units) below what was measured, within the range that was stated.
By their numbers in this assay, from the lowest: compound 2; then compounds 4 and 1 (each within the scatter of the next).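

The aromatic ring proves to be a place where a small edit counts: in this assay, replacing fluoro with hydrogen on an aromatic carbon, para to a large group, gives a 2.7-fold higher number from compound 2 to compound 4 (0.43 log units; beyond the scatter). The chain is identical in both compounds, so this single atom change accounts for the whole difference. No measurement available gives a reason for the shift. As far as these compounds go, whether chloro or methoxy in the same place would match fluoro remains open. So does whether the 4-fluorophenyl to phenyl change would cost as much on the chain of compound 3.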